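Phenyl to cyclopropyl on an amide-type nitrogen

A few compounds are considered here, and "the series" means these few. Any claim that something is new, unique, unknown or untested is made for them only; others in the source may bear on it.

Compound 1 `O=C(Nc1ccccc1)Nc1ccc(-c2nc(N3CC4CCC(C3)O4)c3cnn(C4CCC5(CC4)OCCO5)c3n2)cc1` is the starting point for this step. In an in vitro ADME assay on microsomes (Mus musculus) for metabolic stability (a lower number here means that the compound disappears faster, a higher number that the compound lasts longer), compound 1 gives > 0.5 h, which is a limit of the assay and not a number. In this assay compound 2 `CNC(=O)Nc1ccc(-c2nc(N3CC4CCC(C3)O4)c3cnn([C@H]4CC[C@@H](O)CC4)c3n2)cc1` gives > 0.5 h, which is also a limit. Among the measured compounds shown here, the measured series so far comes down to the limit of > 0.5 h in this assay, at which 2 of the 2 values shown sit. For the measured compounds named here, no step between measured compounds is available.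

Compound 3 `O=C(Nc1ccc(-c2nc(N3CC4CCC(C3)O4)c3cnn(C4CCC5(CC4)OCCO5)c3n2)cc1)NC1CC1` carries cyclopropyl in place of phenyl on an amide-type nitrogen, and the rest of compound 1 is kept: cyclopropyl in place of phenyl on an amide-type nitrogen. No change beyond the usual scatter is expected in this assay, so no direction is assigned, and the estimated step is a step that the limit leaves unreadable from compound 1 to compound 3. This expectation rests only on compound 1 with its limit of > 0.5 h. For compound 3 the estimated half-life is 0.6 h, with an expected range of 0.3 h to 1.2 h.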

Compound 3, half-life: 0.417 h
Estimate against measurement, compound 3: 1.4-fold (0.16 log units) above; the measured number falls inside the stated range.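

Compound 3 is the only compound shown with a number rather than a limit in this assay, and there compound 3 gives 0.417 h. Compound 1 stays at > 0.5 h, which is a limit of the assay and not a number. Cyclopropyl in place of phenyl on an amide-type nitrogen therefore reads only as an at least 1.1-fold lower number from compound 1 to compound 3 (0.07 log units; that floor lies within the scatter), and no real change can be claimed, because the comparison rests on a limit: the limit of > 0.5 h in this assay, at which 2 of the 3 values shown sit.

Still open, on these data alone, is how far the true half-life of compound 1 lies from that of compound 3. Also open, as far as these compounds go, is whether an isopropyl group, a pyridyl ring or a longer chain such as n-butyl on the same nitrogen would give a step beyond the scatter from compound 3.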